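The source may hold more compounds than are shown below. What is called first, only, known or untested is meant among the compounds shown, and "the series" means these compounds.

Measured in a functional assay on HCT-116 cells (Homo sapiens) for inhibition, read by colorimetric assay, with a stated time of 3 days; on this read-out higher numbers stand for weaker inhibition and lower numbers for stronger inhibition:
compound 1 `COc1ccc(NC(=O)CCCCCCNC(=O)C(O)(O)C(F)(F)F)cc1`: 4520 nM
compound 2 `O=C(CCCCCCNC(=O)C(O)(O)C(F)(F)F)Nc1ccc(Br)cc1`: 3130 nM
compound 3 `COc1ccccc1NC(=O)CCCCCCNC(=O)C(O)(O)C(F)(F)F`: 10100 nM

Of these three, compound 3 has the highest number, 10100 nM, which makes it the weakest inhibitor of the set. The change considered here turns it into compound 4 `O=C(CCCCCCNC(=O)C(O)(O)C(F)(F)F)Nc1c(F)cc(F)cc1F`: 2,4,6-trifluorophenyl in place of 2-methoxyphenyl on an amide-type nitrogen. In words, this puts 2,4,6-trifluorophenyl in place of 2-methoxyphenyl on an amide-type nitrogen.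

Two measured steps change the group at this same place and end at compound 3: a 2.2-fold higher number from compound 1 to compound 3 (0.35 log units; beyond the scatter) and a 3.2-fold higher number from compound 2 to compound 3 (0.51 log units; beyond the scatter). Read backwards, both suggest that leaving 2-methoxyphenyl may lower the number modestly. A third step, a 1.4-fold lower number from compound 1 to compound 2 (0.16 log units; within the scatter), shows that bromo and methoxy are not told apart here. Within the data shown here, no measured compound carries fluorine, so this guidance is loose, and a modest drop toward stronger inhibition is all that can be expected. The expected step is a 1.8-fold lower number from compound 3 to compound 4 (0.26 log units; within the scatter). For compound 4 the estimated value is 5500 nM, with an expected range from 2500 nM to 12000 nM.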

Compound 4, half-maximal inhibitory concentration: 22200 nM
For compound 4 the middle estimate is 4.0-fold (0.61 log units) below the measured one, outside the stated range (above it).
By their numbers in this assay, from the lowest: compounds 2 and 1 (each within the scatter of the next); then compound 3; then compound 4.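

In this assay, 2,4,6-trifluorophenyl on the amide-type nitrogen gives the weakest inhibitor of the four compounds, with a 2.2-fold higher number from compound 3 to compound 4 (0.34 log units; beyond the scatter) and a 4.9-fold higher number from compound 1 to compound 4 (0.69 log units; beyond the scatter) and a 7.1-fold higher number from compound 2 to compound 4 (0.85 log units; beyond the scatter). The earlier compounds shown here put 2-methoxyphenyl at the weak end, but this change shows that the group at this place can weaken inhibition further, and the gap between the groups tried here is now wider than those compounds suggested. Nothing measured here explains this drop in inhibition.

From the compounds shown here alone, it remains open whether a phenyl ring carrying a single fluorine, or a plain phenyl ring, would fall nearer compound 2 or compound 4. Going by these compounds, how an amine or a carboxylic acid on this ring would change the number also stays unknown.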